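This account rests on a few compounds, and the source may have more. Where it says the series, first, only, none or still open, it means among the compounds named here.

Working notes on the series

Compound 1 `CC1(C)COC(c2cccc(OC(=O)NC3CCCCC3)c2)=N1` gives 46 nM in an assay (strain Wistar) for inhibition of Fatty-acid amide hydrolase 1 (Rattus norvegicus), read by scintillation counting; on this read-out higher numbers stand for weaker inhibition and lower numbers for stronger inhibition. Compound 2 `C[C@@H]1COC(c2cccc(OC(=O)NC3CCCCC3)c2)=N1` gives 16 nM in this assay. Among the measured compounds shown here, the one measured step, a 2.9-fold lower number from compound 1 to compound 2 (0.46 log units; beyond the scatter), exchanges the substitution on the five-membered ring bearing two hetero atoms and is the only step recorded so far. Compound 2 therefore stands at the lowest of the two numbers in this assay, with compound 1 as its nearest neighbour.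

Compound 3 `O=C(NC1CCCCC1)Oc1cccc(C2=N[C@H](Cc3ccccc3)CO2)c1` is not yet measured. Relative to compound 2 the change is phenyl in place of hydrogen on a saturated chain carbon bound to a saturated ring carbon. For the measured compounds named here, no measured step adds a group at this place; the step from compound 1 to compound 2 touched the same ring but removed rather than added a group, so it bears on compound 3 only indirectly and with a modest size. The expectation for compound 3 in this assay is therefore a step of a 1.6-fold higher number from compound 2 to compound 3 (0.19 log units; within the scatter), which is estimated to stay within or close to the scatter. Compound 3 is expected to give about 25 nM in this assay, in a range from 6 nM to 100 nM.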

Compound 3, half-maximal inhibitory concentration: 590 nM
Estimate against measurement, compound 3: 24-fold (1.37 log units) below, outside the stated range (above it).
By their numbers in this assay, from the lowest: compound 2; then compound 1; then compound 3.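

In this assay, phenyl in place of hydrogen on a saturated chain carbon bound to a saturated ring carbon, which also reads as methyl to benzyl, gives a 37-fold higher number from compound 2 to compound 3 (1.57 log units; beyond the scatter), a large step that far exceeds the modest 2.9-fold lower number from compound 1 to compound 2 (0.46 log units; beyond the scatter). The earlier pair showed only a modest change in the number with the substitution on this ring, whereas compound 3 shows that a group entering at this place can raise the number strongly, so this place does not take every group alike. Nothing at hand gives a reason for the size of this step.

The compounds shown leave open whether the rise goes with the aromatic ring itself or with any larger group here: ethyl, isopropyl or cyclohexylmethyl in place of the methyl of compound 2 would separate these two readings. They also leave open how a hydroxymethyl or an aminomethyl group at the same place would read in this assay, and so whether the number rises steadily with the size of the group or only with benzyl.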